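Cyano in Place of Hydrogen: Notes Toward Compound 4

The source may hold more compounds than are shown below. What is called first, only, known or untested is meant among the compounds shown, and "the series" means these compounds.

Of the compounds shown here, three have been measured in a functional assay on NCI-H1975 cells (Homo sapiens) for antiproliferative activity, read by MTT assay, with a stated time of 72 h; a lower number here means a stronger inhibitor, a higher number a weaker inhibitor. Compound 1 `CCC/C=C\C(=O)Nc1cc(Nc2nccc(-c3cn(C)c4ccccc34)n2)c(OC)cc1N(C)CCN(C)C` gives 1220 nM. Compound 2 `CCC/C=C\C(=O)Nc1cc(Nc2ncc(C#N)c(-c3cn(C)c4ccccc34)n2)c(OC)cc1N(C)CCN(C)C` gives 823 nM; it differs from compound 1 by cyano in place of hydrogen on an aromatic carbon, and the step is a 1.5-fold lower number from compound 1 to compound 2 (0.17 log units; within the scatter). Compound 3 `C=CC(=O)Nc1cc(Nc2nccc(-c3cn(C)c4ccc(F)cc34)n2)c(OC)cc1N(C)CCN(C)C` gives 254 nM, the lowest of the three numbers, standing beyond the scatter from both compound 1 and compound 2. The difference between the core of compound 3 and the core of compound 1 is not broken down here.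

Compound 4 `C=CC(=O)Nc1cc(Nc2ncc(C#N)c(-c3cn(C)c4ccc(F)cc34)n2)c(OC)cc1N(C)CCN(C)C` is not yet measured. It differs from compound 3 by cyano in place of hydrogen on an aromatic carbon. This is the same kind of change as that from compound 1 to compound 2; around the place it differs in that the cyano sits ortho to a 5-fluoro-1-methyl-1H-indol-3-yl group rather than ortho to a 1-methyl-1H-indol-3-yl group. In this assay the step from compound 3 to compound 4 is expected to be a 1.4-fold lower number from compound 3 to compound 4 (0.15 log units; within the scatter), resting on the earlier step of a 1.5-fold lower number from compound 1 to compound 2 (0.17 log units; within the scatter) seen in the same kind of change. Compound 4 is therefore estimated at 180 nM, with a range from 90 nM to 400 nM.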

Compound 4, half-maximal inhibitory concentration: 11400 nM
Compound 4: the middle estimate sits 63-fold (1.80 log units) below what was measured; the measured number lies above the stated range.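

On the core of compound 3, cyano in place of hydrogen gives a 45-fold higher number from compound 3 to compound 4 (1.65 log units; beyond the scatter) in this assay, so the result on the core of compound 1 does not carry over to this second core, and the two steps are clearly different: the same change on two cores in this assay, a 1.5-fold lower number (0.17 log units; within the scatter) from compound 1 to compound 2 and a 45-fold higher number (1.65 log units; beyond the scatter) from compound 3 to compound 4, 67-fold (1.82 log units) apart, beyond the scatter of two such steps

The outcome of this change therefore depends on the core in these two pairs, and a step measured on one core is a poor guide to the same step on the other. What lies behind the split is not shown: the two cores differ in more than one place, and two pairs give no rule for any other core in the series.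

The compounds shown leave open whether the large step on the core of compound 3 goes with the 5-fluoro-1-methyl-1H-indol-3-yl group or with the amide side chain, as no pair varies one of these alone. Also open, as far as these compounds go, is whether chlorine or trifluoromethyl at the same aromatic carbon would follow hydrogen or cyano on either core.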